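This account rests on a few compounds, and the source may have more. Where it says the series, first, only, none or still open, it means among the compounds named here.

Measured so far in a functional assay on P388 cells (Mus musculus) for inhibition; on this read-out lower numbers stand for stronger inhibition and higher numbers for weaker inhibition:
compound 1 `COc1cccc(/C=C2\Cc3ccccc3C2=O)c1OC` gives 28700 nM
compound 2 `O=C1/C(=C/c2ccccc2[N+](=O)[O-])CCc2ccccc21` gives 12600 nM

Compound 2 holds the lower of the two numbers, so it is the stronger inhibitor of this pair, and its gap to compound 1 lies beyond the usual scatter. Going by the values given here, no step between measured compounds that differ in one place is available, so the series offers no direct guide to the effect of a single change.

The compound still to be measured is compound 3 `O=C1/C(=C/c2ccccc2Br)CCc2ccccc21` and its change from compound 2 reads bromo in place of nitro on an aromatic carbon (bromo in place of nitro on an aromatic carbon, ortho to a large group). In this assay no step beyond the scatter is expected, and neither direction is favoured. This expectation has compound 1 at 28700 nM and compound 2 at 12600 nM as its only anchors, so the range is kept wide. The expected step is a 1.1-fold lower number from compound 2 to compound 3 (0.02 log units; within the scatter) and it stays within the scatter. Compound 3 is estimated at 12000 nM (range 4500 nM to 32000 nM).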

Compound 3, half-maximal inhibitory concentration: 19700 nM
For compound 3 the middle estimate is 1.6-fold (0.22 log units) below the measured one; the measured number falls inside the stated range.
By their numbers in this assay, from the lowest: compounds 2, 3 and 1 (each within the scatter of the next, the first and the last beyond it).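

In this assay the series now has its first single-place step: bromo in place of nitro on an aromatic carbon, ortho to a large group, gives a 1.6-fold higher number from compound 2 to compound 3 (0.19 log units; within the scatter), which stays within the scatter. At this place, then, nitro with its 3 heavy atoms and 2 hydrogen-bond acceptors and bromo with 1 heavy atom and 0 hydrogen-bond acceptors cannot be told apart by this read-out, so neither the heavy-atom count nor the acceptor count of the group shows a readable link to the number across this one pair. No measurement at hand gives a reason for this result.

Two groups at one place cannot show whether the position accepts substituents broadly, and an amine or a carboxylic acid on the same aromatic carbon would test this more sharply than another neutral group. Compound 1 differs from compound 2 and compound 3 in more than one place, so the contribution of its two methoxy groups, and of its different core, remains unresolved.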